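Phenoxy for ethyl at the anilide ring, cytotoxicity unchanged?

A few compounds are considered here, and "the series" means these few. Any claim that something is new, unique, unknown or untested is made for them only; others in the source may bear on it.

Compound 1 `O=C(Nc1cccc(N2CCCC2=O)c1)C1CCCN(C(=O)c2cc(C(F)(F)F)cc(C(F)(F)F)c2)C1`: 0%
Compound 2 `CCc1cccc(NC(=O)C2CCCN(C(=O)c3cc(C(F)(F)F)cc(C(F)(F)F)c3)C2)c1`: 0%

In an ADME assay on PC-3 cells (Homo sapiens) for cytotoxicity, read by WST assay, tested at 100 uM (a higher number here means more inhibition at the concentration tested (going by the name of the read-out), a lower number less inhibition), compound 1 gives 0% and compound 2 gives 0%. Going by the values given here, the one step measured so far, no change at the digits printed from compound 1 to compound 2 (within the scatter), leaves the read-out where it stood, so compound 2 stands level with compound 1. Compound 3 `O=C(Nc1cccc(Oc2ccccc2)c1)C1CCCN(C(=O)c2cc(C(F)(F)F)cc(C(F)(F)F)c2)C1` carries phenoxy in place of ethyl on an aromatic carbon. Among the compounds with values here, no measured step bears directly on a phenoxy group, and the only step known stayed within the scatter, so the expected step of a number 3 percentage points higher from compound 2 to compound 3 (within the scatter) is none beyond the scatter. Compound 3 is therefore estimated at 3%, in the range 0% to 20%.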

Compound 3, a percentage reported as inhibition, at one concentration (the size of the read-out at that concentration, not a potency): 1%
Compound 3: the middle estimate sits 2 percentage points above what was measured; the range from low to high includes it.
By their numbers in this assay, from the lowest: compounds 1, 2 and 3 (each within the scatter of the next).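

Within this assay the exchange of ethyl for phenoxy gives a number 1 percentage points higher from compound 2 to compound 3 (within the scatter) and the exchange of 2-oxopyrrolidin-1-yl for phenoxy gives a number 1 percentage points higher from compound 1 to compound 3 (within the scatter) at the same position. A group bearing a six-membered aromatic ring of carbon only thus joins ethyl and 2-oxopyrrolidin-1-yl within the scatter of one another. Nothing measured here offers an explanation for this result.

The compounds shown leave open whether an amine or a carboxylic acid at this position would read differently. They also leave open whether replacing a trifluoromethyl group would do so.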